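Phenyl Sulfonamide Benzylamides: Swapping the Aryl Amide Substituent

The source may hold more compounds than are shown below. What is called first, only, known or untested is meant among the compounds shown, and "the series" means these compounds.

Measured so far: compound 1 `O=C(NCc1ccc(CNS(=O)(=O)c2ccccc2)cc1)c1cccnc1` gives 10 nM; compound 2 `Cc1cccc(C(=O)NCc2ccc(CNS(=O)(=O)c3ccccc3)cc2)c1` gives 1000 nM.

In an assay on MDA-MB-231 cells for binding affinity to C-X-C chemokine receptor type 4 (Homo sapiens), read by immunofluorescence and microscopy, with stated times of 10 min and 30 min (a higher number here means that more compound is needed for the effect, a lower number that less compound is needed), compound 2 stands highest of the two numbers, its nearest neighbour compound 1 sitting at a 100-fold higher number from compound 1 to compound 2 (2.00 log units; beyond the scatter). Compound 3 `O=C(NCc1ccc(CNS(=O)(=O)c2ccccc2)cc1)c1ccc(Cl)cc1` differs from compound 2 by 4-chlorophenyl in place of 3-methylphenyl on a carbonyl carbon. Within the data shown here, the only measured step, from pyridin-3-yl to 3-methylphenyl, is large, but it exchanges a heteroaryl for a carbocycle and does not speak directly to one substituted phenyl replacing another. No step beyond the scatter is therefore expected in this assay; compound 3 is estimated at 1000 nM (range 200 nM to 5000 nM), a step of no change at the digits printed from compound 2 to compound 3 (within the scatter).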

Compound 3, effective concentration (reported as EC, without a stated level of effect): 100 nM
Estimate against measurement, compound 3: 10-fold (1.00 log units) above; the whole stated range lies above it.
By their numbers in this assay, from the lowest: compound 1; then compound 3; then compound 2.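

In this assay, the aryl group on the carbonyl carbon matters even when one substituted phenyl replaces another: 4-chlorophenyl in place of 3-methylphenyl gives a 10-fold lower number from compound 2 to compound 3 (1.00 log units; beyond the scatter). Neither phenyl group matches pyridin-3-yl, and 4-chlorophenyl in its place still gives a 10-fold higher number from compound 1 to compound 3 (1.00 log units; beyond the scatter). Nothing given here accounts for either step.

The compounds shown leave open whether the gain follows the chlorine or its place on the ring, which 4-methylphenyl or 3-chlorophenyl would help separate. On these data alone, how pyridin-4-yl would compare with pyridin-3-yl also remains open.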